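Two Thienoyl Selenoureas, a Methyl Swapped for Benzyl

The compounds below may be only part of what the source reports. "The series", "measured", "known", "first", "only" and "open" are said of these compounds alone.

Compound 1, `C[Se]/C(=N\C(=O)c1cc2ccccc2s1)NC(=O)c1cc2ccccc2s1`, in an ADME assay on MCF-10A cells (Homo sapiens) for cytotoxicity, read by MTT assay, with a stated time of 72 h (on this read-out higher numbers stand for weaker inhibition of growth and lower numbers for stronger inhibition of growth), gives 490 nM.
Compound 2, `C[Se]/C(=N\C(=O)c1cccs1)NC(=O)c1cccs1`, in this assay gives 9260 nM.
Compound 3, `O=C(/N=C(/NC(=O)c1ccno1)[Se]Cc1ccccc1)c1ccno1`, in this assay gives 7800 nM.

Among these three, compound 2 carries the highest number in this assay, meaning the weakest inhibition of growth. Its nearest neighbour is compound 3, whose number lies within the usual scatter of compound 2, so the two cannot be placed in order. Compound 1 stands far apart, with a number well beyond the scatter below that of compound 2.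

Compound 4, `O=C(/N=C(/NC(=O)c1cccs1)[Se]Cc1ccccc1)c1cccs1`, shares the core of compound 2 and differs in one place: phenyl in place of hydrogen on a saturated chain carbon bound to a selenium atom. For the measured compounds named here, no pair of measured compounds shows this same change on its own, so its effect in this assay is not known from the data. Compound 3, which also carries a benzyl on selenium but with a different core, sits close to compound 2 in this assay; that is a weak hint at most.

For compound 4 the expected step is a 1.9-fold lower number from compound 2 to compound 4 (0.27 log units; within the scatter), a shift not confidently beyond the scatter in either direction. The estimate for compound 4 in this assay is 5000 nM, expected to fall between 1500 nM and 16000 nM.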

Compound 4, concentration for 50% growth inhibition: 72500 nM
For compound 4 the middle estimate is 15-fold (1.16 log units) below the measured one; measured number outside the range, above it.
By their numbers in this assay, from the lowest: compound 1; then compounds 3 and 2 (each within the scatter of the next); then compound 4.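

In this assay, the swap of methyl to benzyl, with phenyl in place of hydrogen on a saturated chain carbon bound to a selenium atom, gives a 7.8-fold higher number from compound 2 to compound 4 (0.89 log units; beyond the scatter), which means weaker inhibition of growth of these cells. For the compounds shown here, this is the first direct reading of the change, since compound 2 and compound 4 differ in this one place only, and it shows that what sits here does alter the read-out, with the benzyl compound the weaker of this pair. No measurement at hand explains the direction or size of this step.

On these data alone, this is a single pair on a single core, so it remains open whether the same swap would go the same way on the core of compound 1 or on the core of compound 3. As far as these compounds go, it is also open how this position would respond to other groups, such as an ethyl group, a longer chain without a phenyl, or a chain ending in an amine or a carboxylic acid.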